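The source may report more compounds than this note shows. Statements on the series, on what has been measured and on what is new or still open speak of the compounds shown alone.

Among the measured compounds shown here, compound 2 `O=c1cc(Cn2cc(-c3ccc(Br)cc3)nn2)c2ccc(O)cc2o1` holds the only plain number in a functional assay on SW-620 cells (Homo sapiens) for inhibition, read by MTT assay, with a stated time of 72 h (a lower number here means a stronger inhibitor, a higher number a weaker inhibitor), where compound 2 gives 97700 nM. Compound 1 `O=c1cc(Cn2cc(CCCCO)nn2)c2ccc(O)cc2o1` reaches only a limit of the assay, (the limit of > 100000 nM in this assay, at which 1 of the 2 values shown sits), and in this assay compound 1 gives > 100000 nM. For the measured compounds named here, the one measured step, an at least 1.0-fold lower number from compound 1 to compound 2 (0.01 log units; that floor lies within the scatter), shows no change beyond the scatter. Compound 3 `CCCCCCc1ccc(-c2cn(Cc3cc(=O)oc4cc(O)ccc34)nn2)cc1` differs from compound 2 by hexyl in place of bromo on an aromatic carbon. Going by the values given here, only that flat step bears on this change, so the expected step of a 1.2-fold lower number from compound 2 to compound 3 (0.09 log units; within the scatter) is small, with no clear direction. Compound 3 is therefore estimated at 80000 nM, within a range from 20000 nM to 300000 nM.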

Compound 3, half-maximal inhibitory concentration: 36800 nM
For compound 3 the middle estimate is 2.2-fold (0.34 log units) above the measured one; the range from low to high includes it.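

Among the compounds shown here, at this aromatic carbon, para to a large group, hexyl in place of bromo gives the first step beyond the scatter in this assay: a 2.7-fold lower number from compound 2 to compound 3 (0.42 log units; beyond the scatter). The position therefore responds to what sits on it, which the earlier flat step could not show. Six carbons in place of one bromine atom cost nothing here, and the number falls modestly.

As far as these compounds go, whether a longer chain or an amine at this carbon would lower the number further stays open. The comparison also rests on few plain numbers: the limit of > 100000 nM in this assay, at which 1 of the 3 values shown sits.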